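The source may hold more compounds than are shown below. What is called first, only, known or untested is meant among the compounds shown, and "the series" means these compounds.

Measured so far in an ADME assay (MDM cells, Homo sapiens) for cytotoxicity, read by resazurin assay, with a stated time of 3 days; a lower number here means a stronger inhibitor, a higher number a weaker inhibitor:

compound 1 `CSc1nnc(COc2ccccc2C2=NOC(c3ccc(Cl)cc3Cl)C2)n1NC(=O)CCl`, where compound 1 gives 2.7 ug/mL
compound 2 `CSc1nnc(COc2ccccc2C2=NOC(c3ccc(Cl)cc3Cl)C2)n1NC(C)=O`, where compound 2 gives 2.7 ug/mL
compound 3 `CC(=O)Nn1c(S)nnc1COc1ccccc1C1=NOC(c2ccc(Cl)cc2Cl)C1`, where compound 3 gives 1.3 ug/mL

Compound 1 and compound 2 differ by chloro in place of hydrogen on a saturated chain carbon bound to a carbonyl carbon, and the step of no change at the digits printed from compound 2 to compound 1 (within the scatter). Compound 3 differs from compound 2 by hydrogen in place of methyl on a sulfur, and the step of a 2.1-fold lower number from compound 2 to compound 3 (0.32 log units; beyond the scatter); compound 3 holds the lowest of the three numbers.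

Compound 4 `O=C(CCl)Nn1c(S)nnc1COc1ccccc1C1=NOC(c2ccc(Cl)cc2Cl)C1` has not yet been measured in this assay. It differs from compound 3 by chloro in place of hydrogen on a saturated chain carbon bound to a carbonyl carbon, the same change as that from compound 2 to compound 1, made on the core of compound 3 rather than the core of compound 2. On the first core that change left the number where it stood, as no change at the digits printed from compound 2 to compound 1 (within the scatter) shows. Resting on that single precedent and on the value of compound 3, 1.3 ug/mL, the step is expected to be small, no change at the digits printed from compound 3 to compound 4 (within the scatter). Compound 4 is therefore estimated at 1.3 ug/mL, between 0.6 ug/mL and 2.8 ug/mL, in this assay.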

Compound 4, half-maximal inhibitory concentration: 3.2 ug/mL
Estimate against measurement, compound 4: 2.5-fold (0.39 log units) below; measured number outside the range, above it.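

On the core with hydrogen on the sulfur, chloro in place of hydrogen on a saturated chain carbon bound to a carbonyl carbon gave, in this assay, a 2.5-fold higher number from compound 3 to compound 4 (0.39 log units; beyond the scatter), while hydrogen in place of methyl on a sulfur, with the chloromethyl group present on both sides, gave a 1.2-fold higher number from compound 1 to compound 4 (0.07 log units; within the scatter). Set beside the earlier step on the other core, the two readings of the chloro change do not differ beyond what repeated measurement allows: the same change on two cores in this assay, no change at the digits printed (within the scatter) from compound 2 to compound 1 and a 2.5-fold higher number (0.39 log units; beyond the scatter) from compound 3 to compound 4, 2.5-fold (0.39 log units) apart, within the scatter of two such steps. These pairs therefore do not show that the change behaves differently on the two cores, nor do they prove that it carries over unaltered, and the same holds for the change on the sulfur: the same change on two cores in this assay, a 2.1-fold lower number (0.32 log units; beyond the scatter) from compound 2 to compound 3 and a 1.2-fold higher number (0.07 log units; within the scatter) from compound 1 to compound 4, 2.5-fold (0.39 log units) apart, within the scatter of two such steps.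

With a single pair for each comparison, the compounds shown leave open whether bromo, methoxy or an amine on that chain carbon would behave alike on both cores. They also leave open whether a longer chain on the carbonyl, or ethyl on the sulfur, would do so.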